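This account rests on a few compounds, and the source may have more. Where it says the series, first, only, none or still open, it means among the compounds named here.

Compound 1 `CCCOc1ccc([C@@H]2CC(=O)c3cc(CC=C(C)C)c(OC)cc3O2)cc1`: 54%
Compound 2 `COc1ccc([C@@H]2C/C(=N/OCc3cn(-c4ccc(C#N)cc4)nn3)c3cc(CC=C(C)C)c(OC)cc3O2)cc1`: 50%

Both numbers come from a functional assay on PC-3 cells (Homo sapiens) for inhibition, read by sulforhodamine B assay, with a stated time of 48 h, tested at 50 uM; a lower number here means less inhibition of growth, a higher number more inhibition of growth at the concentration tested. Compound 1 and compound 2 lie within the usual scatter of repeated measurements, so the two cannot be ranked against each other. Among the compounds with values here, compound 1 therefore stands level with the only other measured compound, and neither one can be called the better of the pair.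

The next compound to be tested is compound 3 `C#CCOc1ccc([C@@H]2CC(=O)c3cc(CC=C(C)C)c(OC)cc3O2)cc1`, which keeps the core of compound 1 and changes in one place: ethynyl in place of ethyl on a saturated chain carbon bound to an oxygen on an aromatic ring. Read one bond further out, this is propyl to propargyl, or propoxy to propargyloxy. Within the data shown here, no measured pair shows what a change of this kind does in this assay, so the data offer no direct precedent. The expectation is therefore no step beyond the scatter, in either direction, and it rests on compound 1 at 54% as the starting point. The estimated change is small: a number 2 percentage points lower from compound 1 to compound 3 (within the scatter). Compound 3 is expected to give about 52%, with an estimated range of 35% to 70%.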

Compound 3, percent growth inhibition at one concentration: 52%
Beside the measured number, compound 3's estimate shows no gap at the digits printed; measured number inside the range.
By their numbers in this assay, from the lowest: compounds 2, 3 and 1 (each within the scatter of the next).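

In this assay, replacing ethyl with ethynyl on a saturated chain carbon bound to an oxygen on an aromatic ring, which is the change from propoxy to propargyloxy, gives a number 2 percentage points lower from compound 1 to compound 3 (within the scatter). Within the data shown here, this is the first pair that differs in only one place, so it gives the first direct reading for this position. Here, a triple bond at the end of this chain leaves the growth inhibition at the tested concentration within the scatter of the propoxy compound, and no measurement shown explains this outcome.

One pair says little about the position as a whole: a longer chain such as butoxy, or a chain ending in an amine or a carboxylic acid, might still produce a step beyond the scatter. A reading at a single concentration also leaves open whether compound 1 and compound 3 would stay level across a range of concentrations, where a difference between them might appear.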